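Trimming the fatty chain of an inactive compound

A few compounds are considered here, and "the series" means these few. Any claim that something is new, unique, unknown or untested is made for them only; others in the source may bear on it.

Within the data shown here, in a functional assay on DU-145 cells (Homo sapiens) for cytotoxicity, read by MTT assay, with a stated time of 24 h (on this read-out lower numbers stand for stronger inhibition and higher numbers for weaker inhibition), compound 1 `CCCCCCCCCCCCCC(=O)Nc1nnc(S[C@@H]2O[C@H](COC(C)=O)[C@H](OC(C)=O)[C@H](OC(C)=O)[C@H]2OC(C)=O)s1` gives 34700 nM as the only number so far. Compound 2 `CCCCCCCCCCCCCCCCCC(=O)Nc1nnc(S[C@@H]2O[C@H](CO)[C@H](O)[C@H](O)[C@H]2O)s1` is recorded as "not active" (no number reported) and so stands without any figure from which to size a step. Compound 3 `CCCCCCCCCCCCCC(=O)Nc1nnc(S[C@@H]2O[C@H](CO)[C@H](O)[C@H](O)[C@H]2O)s1` has yet to be measured. The change hydrogen in place of butyl on a saturated chain carbon, ten or more bonds along the chain from a carbonyl carbon puts hydrogen in place of butyl on a saturated chain carbon. Only a modest move towards stronger inhibition is expected in this assay and compound 3 may also end up without a number. If a number is reported, compound 3 is estimated at 60000 nM with an expected range from 25000 nM to 150000 nM for that reading.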

Compound 3, half-maximal inhibitory concentration: "not active" (no number reported)
No number was reported for compound 3; the estimate stays without a comparison.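

In this assay compound 2 and compound 3 are both recorded as not active without a number, so no step can be read between them. Nothing measured here offers an explanation. Going by these compounds, whether hydrogen in place of butyl changes the read-out at all stays open.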